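A Nitro Group Replaces Iodo in a Small Series

The source may hold more compounds than are shown below. What is called first, only, known or untested is meant among the compounds shown, and "the series" means these compounds.

Values in a functional assay on U-87MG ATCC cells (Homo sapiens) for cytotoxicity, read by MTT assay, with a stated time of 48 h (a higher number here means a weaker inhibitor, a lower number a stronger inhibitor), so far:
Compound 1 `C/C(=N\NC(=S)Nc1cccc(F)c1)c1ccccn1` gives 18 nM as its measured value
Compound 2 `C/C(=N\NC(=S)Nc1cccc(I)c1)c1ccccn1` gives 84 nM as its measured value
Compound 3 `C/C(=N\NC(=S)Nc1cccc([N+](=O)[O-])c1)c1ccccn1` has not yet been measured

Going by the values given here, with 84 nM as its value, compound 2 holds the higher of the two numbers in this assay so far. Compound 3 carries nitro in place of iodo on an aromatic carbon, meta to a large group nitro in place of iodo on an aromatic carbon in the structure. Among the compounds with values here, only one measured step bears on this change, and it is modest: a 4.7-fold higher number from compound 1 to compound 2 (0.67 log units; beyond the scatter) on going from fluoro to iodo. Within the data shown here, no measured compound carries nitro, so that step offers only loose guidance. A step of similar or smaller size toward a lower number is therefore expected, and the estimate amounts to a 2.1-fold lower number from compound 2 to compound 3 (0.32 log units; beyond the scatter) in all. For compound 3 the expected value is 40 nM with an estimated range from 12 nM to 130 nM in this measurement.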

Compound 3, half-maximal inhibitory concentration: 69 nM
The estimate for compound 3 lay 1.7-fold (0.24 log units) below the measured number; the measured number falls inside the stated range.
By their numbers in this assay, from the lowest: compound 1; then compounds 3 and 2 (each within the scatter of the next).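

In this assay, nitro in place of iodo gives a 1.2-fold lower number from compound 2 to compound 3 (0.09 log units; within the scatter), so on this aromatic carbon the two groups cannot be told apart, although they share neither their atoms nor their hydrogen-bond acceptor count. Nitro in place of fluoro gives a 3.8-fold higher number from compound 1 to compound 3 (0.58 log units; beyond the scatter), which shows that the earlier gap was not peculiar to iodo: compound 1 now stands apart from both other compounds as the strongest of the three, with each of its steps beyond the scatter. Nothing available accounts for fluoro standing apart from iodo and nitro. The compounds shown leave open whether an amine or a carboxylic acid on this aromatic carbon would fall with compound 1 or with compounds 2 and 3. They also leave open whether chloro, the halogen closest to fluoro in this comparison, would keep the low number of compound 1.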